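Methyl added on the anilide ring of compound 3

The source may report more compounds than this note shows. Statements on the series, on what has been measured and on what is new or still open speak of the compounds shown alone.

Compound 3 `O=C(CN1CCC(c2cccc[n+]2[O-])CC1)Nc1cccc(Cl)c1` gives 76% in a functional assay on HEK293 cells for agonist activity at D(4) dopamine receptor (Homo sapiens), read by FLIPR (on this read-out lower numbers stand for smaller maximal responses and higher numbers for larger maximal responses), the highest of the three numbers shown. Compound 1 `Cc1cc(NC(=O)CN2CCC(c3cccc[n+]3[O-])CC2)ccc1F` gives 75%, and the step of a number 1 percentage points higher from compound 1 to compound 3 (within the scatter) lies within the scatter, so the two cannot be ordered. Compound 2 `O=C(CN1CCC(c2cccc[n+]2[O-])CC1)Nc1ccccc1F` gives 63%, and the step of a number 13 percentage points higher from compound 2 to compound 3 (beyond the scatter) is beyond the scatter, as is a number 12 percentage points lower from compound 1 to compound 2 (beyond the scatter).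

Compound 4 `Cc1ccc(Cl)cc1NC(=O)CN1CCC(c2cccc[n+]2[O-])CC1` differs from compound 3 by methyl in place of hydrogen on an aromatic carbon, the entering methyl sitting ortho to a large group and para to the chloro group. For the measured compounds named here, no measured step adds a methyl alone. The nearest case, a number 1 percentage points higher from compound 1 to compound 3 (within the scatter), removes a methyl together with a fluoro-for-chloro exchange and stays within the scatter, which argues for a small effect of the methyl. The two steps beyond the scatter, a number 12 percentage points lower from compound 1 to compound 2 (beyond the scatter) and a number 13 percentage points higher from compound 2 to compound 3 (beyond the scatter), both involve compound 2 and a different ring pattern, so they do not speak directly to this change.

The expectation is therefore a step of a number 4 percentage points lower from compound 3 to compound 4 (within the scatter), within the scatter. Compound 4 is estimated at 72%, with a range from 58% to 86%.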

Compound 4, largest response reached (reported as efficacy), in percent of the reference or control that the assay uses: 58%
For compound 4 the middle estimate is 14 percentage points above the measured one; the measured number falls inside the stated range.
By their numbers in this assay, from the lowest: compounds 4 and 2 (each within the scatter of the next); then compounds 1 and 3 (each within the scatter of the next).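

In this assay, for the compounds shown here, a number 18 percentage points lower from compound 3 to compound 4 (beyond the scatter) is the first step that changes a methyl alone, and it shows that methyl in place of hydrogen on this aromatic carbon, ortho to a large group and para to a chloro group, is not silent on the 3-chlorophenyl ring. With a number 17 percentage points lower from compound 1 to compound 4 (beyond the scatter) beyond the scatter and a number 5 percentage points lower from compound 2 to compound 4 (within the scatter) within it, the 5-chloro-2-methylphenyl compound groups with the 2-fluorophenyl compound rather than with the other methyl-bearing compound, so among these four compounds the lower numbers go with a substituent ortho to the large group, and no compound shown goes against this. No measured evidence on the origin of the lower maximal response accompanies these compounds.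

From the compounds shown here alone, it remains open whether the lower number belongs to methyl specifically or to any group on this carbon, which an ethyl, a methoxy or an amine at the same place would test. Also open, going by these compounds, is whether the same methyl would give a step of similar size on a ring without the chloro group, such as a plain 2-methylphenyl on the amide nitrogen.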